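Undrawn stereocentre in compound 3: expected consequence

The source may report more compounds than this note shows. Statements on the series, on what has been measured and on what is new or still open speak of the compounds shown alone.

Measured, in an assay on membranes from brain for displacement of a labelled ligand from Sigma non-opioid intracellular receptor 1 (Cavia porcellus), read by radioligand binding; a higher number here means a weaker inhibitor, a lower number a stronger inhibitor:
compound 1, `CCN(CCCCc1cn(-c2ccc(F)cc2)c2ccccc12)[C@H]1CCc2c1ccc(OC)c2OC`, gives 50.8 nM
compound 2, `COc1ccc2c(c1OC)CC[C@@H]2NCCCCc1cn(-c2ccc(F)cc2)c2ccccc12`, gives 122 nM

Compound 1 holds the lowest of the two numbers in this assay. Within the data shown here, the only measured step, a 2.4-fold higher number from compound 1 to compound 2 (0.38 log units; beyond the scatter), is modest and beyond the scatter; the change there is hydrogen in place of ethyl on an amine nitrogen. Compound 3, `CCN(CCCCc1cn(-c2ccc(F)cc2)c2ccccc12)C1CCc2c1ccc(OC)c2OC`, is not yet measured. It differs from compound 1 only as follows: the two compounds have the same atoms and bonds; at least one stereo element is drawn with a configuration in one of them and without one in the other: 1 of 1 stereo elements differ; a stereocentre at a saturated ring carbon is drawn S in compound 1 and without a configuration in compound 3. Among the measured compounds shown here, no measured step concerns a configuration drawn or left undrawn; the one known step involves a substituent on the amine nitrogen and gives no guide here. With the same atoms and bonds and only the drawn configuration differing, a number near compound 1 or somewhat higher is expected for compound 3, a 1.6-fold higher number from compound 1 to compound 3 (0.20 log units; within the scatter). Compound 3 is accordingly estimated at 80 nM, with a range from 35 nM to 200 nM.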

Compound 3, inhibition constant: 59.2 nM
Estimate against measurement, compound 3: 1.4-fold (0.13 log units) above, within the range that was stated.
By their numbers in this assay, from the lowest: compounds 1 and 3 (each within the scatter of the next); then compound 2.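

Among these compounds, at the saturated ring carbon, this assay gives the first reading on configuration, with a 1.2-fold higher number from compound 1 to compound 3 (0.07 log units; within the scatter) and so no separation between the drawn S form and the undrawn form. The earlier step spoke only to the substituent on the amine nitrogen, so this pair adds that, with ethyl kept in place, the drawing at this carbon leaves the number within the scatter. The pair can say no more about the configuration itself, since the only difference between the two compounds lies in how this centre is drawn: the fact that one of compounds 1 and 3 is drawn with a defined configuration and the other without, at the place where they differ.

The opposite configuration, drawn R at this carbon, lies outside the compounds shown, so any preference between the two forms remains open. Also open, from the compounds shown here alone, is how a propyl group or a longer chain on the amine nitrogen would compare with ethyl.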